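A few compounds are considered here, and "the series" means these few. Any claim that something is new, unique, unknown or untested is made for them only; others in the source may bear on it.

In a functional assay on MCF7 cells (Homo sapiens) for cytotoxicity, read by MTT assay (on this read-out higher numbers stand for weaker inhibition and lower numbers for stronger inhibition), compound 1 (`CCOc1ccc(O)c(C(=O)/C=C/c2ccc(C)s2)c1`) gives 23200 nM and compound 2 (`CCCOc1ccc(O)c(C(=O)/C=C/c2ccc(C)s2)c1`) gives 21500 nM while compound 3 (`Cc1ccc(/C=C/C(=O)c2cc(OC(C)C)ccc2O)s1`) gives 15500 nM and so compound 1 stands within the scatter of both others. Compound 4 (`Cc1ccc(/C=C/C(=O)c2cc(OCC(C)C)ccc2O)s1`), not yet measured, carries isopropyl in place of methyl on a saturated chain carbon bound to an oxygen on an aromatic ring and the same difference reads as ethoxy to isobutoxy. The measured steps on this same chain bear on the change: there is a 1.1-fold lower number from compound 1 to compound 2 (0.03 log units; within the scatter) and a 1.5-fold lower number from compound 1 to compound 3 (0.18 log units; within the scatter) and also a 1.4-fold lower number from compound 2 to compound 3 (0.14 log units; within the scatter) and each of them lies within the scatter. None of the three measured chains departs from the others beyond the scatter, so no step beyond the scatter is expected for compound 4 in this assay although its chain has not been tested. The estimated step is a 1.4-fold lower number from compound 1 to compound 4 (0.14 log units; within the scatter) and it is expected to stay within the scatter. Compound 4 is estimated at 17000 nM with an expected range from 9000 nM to 30000 nM.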

Compound 4, half-maximal inhibitory concentration: 13000 nM
Beside the measured number, compound 4's estimate is 1.3-fold (0.12 log units) above it; measured number inside the range.
By their numbers in this assay, from the lowest: compounds 4, 3, 2 and 1 (each within the scatter of the next).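

In this assay there is a 1.8-fold lower number from compound 1 to compound 4 (0.25 log units; within the scatter), and alongside it there is a 1.2-fold lower number from compound 3 to compound 4 (0.08 log units; within the scatter) and a 1.7-fold lower number from compound 2 to compound 4 (0.22 log units; within the scatter). This shows that isobutyl on the oxygen on the aromatic ring, a chain branched further out than any earlier one, still gives no step beyond the scatter from any of the three ethers before it. The methyl that turns a straight chain into a branched one also reads alike in two places: the same change on two cores in this assay, a 1.5-fold lower number (0.18 log units; within the scatter) from compound 1 to compound 3 and a 1.7-fold lower number (0.22 log units; within the scatter) from compound 2 to compound 4, 1.1-fold (0.04 log units) apart, within the scatter of two such steps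

All four compounds carry only small saturated chains on this oxygen, so no step beyond the scatter has yet been seen at this position. Going by these compounds, whether a longer chain such as octyl, or an amine or a carboxylic acid in place of isobutyl, would produce such a step stays open.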